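Amide Ring Swaps on a Shared Core

A few compounds are considered here, and "the series" means these few. Any claim that something is new, unique, unknown or untested is made for them only; others in the source may bear on it.

Compound 1 `CNc1ncnc2c(CNc3cc(NC(=O)c4cccc(C(F)(F)F)c4)ccc3C)cccc12`: 433 nM
Compound 2 `CNc1ncnc2c(CNc3cc(NC(=O)c4ccnnc4)ccc3C)cccc12`: 61700 nM
Compound 3 `CNc1ncnc2c(CNc3cc(NC(=O)c4ccc(Br)s4)ccc3C)cccc12`: 10500 nM

In a functional assay on A375P cells (Homo sapiens) for cytotoxicity, read by MTT assay, with a stated time of 24 h (on this read-out lower numbers stand for stronger inhibition and higher numbers for weaker inhibition), compound 3 gives 10500 nM, the second highest of the three numbers; it lies nearer compound 2, separated by a 5.9-fold lower number from compound 2 to compound 3 (0.77 log units; beyond the scatter), than compound 1, separated by a 24-fold higher number from compound 1 to compound 3 (1.38 log units; beyond the scatter). Compound 4 `CNc1ncnc2c(CNc3cc(NC(=O)c4cc(C)on4)ccc3C)cccc12` keeps the shared core and differs from compound 3 in one place: 5-methyl-1,2-oxazol-3-yl in place of 5-bromothiophen-2-yl on a carbonyl carbon. Going by the values given here, the steps that bear on this all vary the ring on the carbonyl carbon: a 140-fold higher number from compound 1 to compound 2 (2.15 log units; beyond the scatter) and a 24-fold higher number from compound 1 to compound 3 (1.38 log units; beyond the scatter) are large, while a 5.9-fold lower number from compound 2 to compound 3 (0.77 log units; beyond the scatter) is modest. Both ring replacements for compound 1 raised the number, so compound 4 is expected to stay in the weak region, with a modest step toward a higher number, a 1.9-fold higher number from compound 3 to compound 4 (0.28 log units; within the scatter). Compound 4 is therefore estimated at 20000 nM, between 5000 nM and 80000 nM.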

Compound 4, half-maximal inhibitory concentration: 1200 nM
Compound 4: the middle estimate sits 17-fold (1.22 log units) above what was measured; measured number below the stated range.
By their numbers in this assay, from the lowest: compound 1; then compound 4; then compound 3; then compound 2.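

In this assay, the ring on the carbonyl carbon proves far more discriminating than its size suggests: with 6 heavy atoms in each group and one five-membered aromatic ring in both, the swap still gives an 8.8-fold lower number from compound 3 to compound 4 (0.94 log units; beyond the scatter). Going by these compounds alone, the 5-methyl-1,2-oxazol-3-yl group also gives a 51-fold lower number from compound 2 to compound 4 (1.71 log units; beyond the scatter), and it is the first replacement to stay fairly close to the 3-(trifluoromethyl)phenyl group, with a 2.8-fold higher number from compound 1 to compound 4 (0.44 log units; beyond the scatter). Nothing available explains this difference between the rings. The compounds leave open whether the 5-methyl group itself contributes, and how an ethyl group or a carboxylic acid in its place would read out.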